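Cytotoxicity notes on an aryl hydrazone series

The compounds below may be only part of what the source reports. "The series", "measured", "known", "first", "only" and "open" are said of these compounds alone.

Measured compounds in an ADME assay on THP-1 cells (Homo sapiens) for cytotoxicity; on this read-out higher numbers stand for weaker inhibition and lower numbers for stronger inhibition:
- compound 1 `COc1ccccc1-c1nnc(-c2ccc(C(=O)N/N=C/c3ccc([N+](=O)[O-])cc3)cc2)o1` gives 203000 nM
- compound 2 `COc1ccccc1-c1nnc(-c2ccc(C(=O)N/N=C/c3ccccn3)cc2)o1` gives 67000 nM
- compound 3 `COc1ccccc1-c1nnc(-c2ccc(C(=O)N/N=C/c3cc(O)ccc3O)cc2)o1` gives 100000 nM

Compound 1 gives the highest number of the three in this assay; its nearest neighbour is compound 3, the furthest is compound 2. Both measured steps away from compound 1 go downward: a 3.0-fold lower number from compound 1 to compound 2 (0.48 log units; beyond the scatter) and a 2.0-fold lower number from compound 1 to compound 3 (0.31 log units; beyond the scatter). The pair compound 2 to compound 3 shows a 1.5-fold higher number from compound 2 to compound 3 (0.17 log units; within the scatter).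

The step to be followed runs from compound 1 to compound 4 `COc1ccccc1-c1nnc(-c2ccc(C(=O)N/N=C/c3ccc(O)cc3)cc2)o1`. The change is hydroxy in place of nitro on an aromatic carbon. The steps from compound 1 to compound 2 and from compound 1 to compound 3 bear on it, since each replaces the 4-nitrophenyl on a carbon with a double bond to nitrogen; both were modest and downward. Among the measured compounds shown here, no measured step replaces only the nitro with a hydroxy, so the expectation rests on those two analogies.

For compound 4 a modest lowering in this assay is therefore expected, estimated as a 1.7-fold lower number from compound 1 to compound 4 (0.23 log units; within the scatter), which may still fall within the scatter. Compound 4 is expected to give about 120000 nM in this assay, with a range from 60000 nM to 240000 nM.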

Compound 4, half-maximal inhibitory concentration: 261000 nM
Compound 4: middle estimate off by 2.2-fold (0.34 log units), on the low side, and the stated range ends below it.
By their numbers in this assay, from the lowest: compounds 2 and 3 (each within the scatter of the next); then compounds 1 and 4 (each within the scatter of the next).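

In this assay, hydroxy in place of nitro on this aromatic carbon, para to a large group, gives a step within the scatter (a 1.3-fold higher number from compound 1 to compound 4 (0.11 log units; within the scatter)), so this single change does not separate the two compounds. The lower numbers of the earlier replacements of 4-nitrophenyl therefore do not follow from removing the nitro alone, since 4-hydroxyphenyl stands clearly apart from both 2,5-dihydroxyphenyl (a 2.6-fold higher number from compound 3 to compound 4 (0.42 log units; beyond the scatter)) and pyridin-2-yl (a 3.9-fold higher number from compound 2 to compound 4 (0.59 log units; beyond the scatter)), and one hydroxy in this place does not reproduce the number seen with the two hydroxy groups of compound 3. The data at hand offer nothing that accounts for these steps.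

Open, as far as these compounds go, is whether an amine or a carboxylic acid on the same aromatic carbon would stay with compound 1 and compound 4 or move toward compound 2 and compound 3 in this assay. Also open, from the compounds shown here alone, is which of the two hydroxy groups of 2,5-dihydroxyphenyl matters for the step to compound 3, and whether a methoxy in place of either hydroxy would keep that lower number.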